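A few compounds are considered here, and "the series" means these few. Any claim that something is new, unique, unknown or untested is made for them only; others in the source may bear on it.

Measured in a functional assay on MCF7 cells (Homo sapiens) for cytotoxicity, read by MTT assay, with a stated time of 72 h; a lower number here means a stronger inhibitor, a higher number a weaker inhibitor:
- compound 1 `Cn1ccc2c(Oc3ccc(NC(=O)c4cc5cccnc5n(-c5ccc(Cl)cc5)c4=O)cc3F)ncnc21`: 75000 nM
- compound 2 `Cn1ccc2c(Oc3ccc(NC(=O)c4cc5cccnc5n(-c5ccc(Br)cc5)c4=O)cc3F)ncnc21`: 59400 nM

Among the compounds with values here, compound 1 stands level with compound 2, the only other measured compound: the step is a 1.3-fold lower number from compound 1 to compound 2 (0.10 log units; within the scatter). Compound 3 `O=C(Nc1ccc(Oc2ncnc3[nH]ccc23)c(F)c1)c1cc2cccnc2n(-c2ccc(Cl)cc2)c1=O` differs from compound 1 at one place: hydrogen in place of methyl on an aromatic nitrogen. Within the data shown here, that measured step is bromo in place of chloro on an aromatic carbon, so it bears only indirectly on this change, and no measured step covers the methyl. No step beyond the scatter is expected in this assay, and the range is kept wide. The expected step is a 1.5-fold lower number from compound 1 to compound 3 (0.18 log units; within the scatter). For compound 3 the estimated value is 50000 nM, with an expected range of 15000 nM to 110000 nM.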

Compound 3, half-maximal inhibitory concentration: 45000 nM
Estimate against measurement, compound 3: 1.1-fold (0.05 log units) above; the measured number falls inside the stated range.
By their numbers in this assay, from the lowest: compounds 3, 2 and 1 (each within the scatter of the next).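

In this assay, the aromatic nitrogen of the five-membered ring tolerates hydrogen as well as methyl, with a 1.7-fold lower number from compound 1 to compound 3 (0.22 log units; within the scatter). This second place on the series thus behaves like the chloro and bromo place, with no step beyond the scatter at either. No available evidence accounts for this result.

As far as these compounds go, whether an ethyl group or a chain ending in an amine on this aromatic nitrogen would give a step beyond the scatter remains open. Also open, from the compounds shown here alone, is whether bromo with hydrogen on that nitrogen would match compound 3.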